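Alkoxy benzamides: swapping the anilide ring for a pyridyl

The compounds below may be only part of what the source reports. "The series", "measured", "known", "first", "only" and "open" are said of these compounds alone.

Compound 1 `COc1ccc(C(=O)Nc2c(F)cccc2F)cc1OC` gives 900 nM in an assay on isolated protein for inhibition of phosphodiesterase 4A (Sus scrofa); a higher number here means a weaker inhibitor, a lower number a stronger inhibitor. Compound 2 `CCCCOc1cc(C(=O)Nc2c(F)cccc2F)ccc1OC` gives 300 nM, and compound 3 `COc1ccc(C(=O)Nc2c(F)cccc2F)cc1OC1CCCCC1` gives 400 nM. The two measured steps that reach beyond the scatter both sit on the alkoxy side of the shared core: a 3.0-fold lower number from compound 1 to compound 2 (0.48 log units; beyond the scatter) and a 2.3-fold lower number from compound 1 to compound 3 (0.35 log units; beyond the scatter). Between the two larger ethers the numbers are close, a 1.3-fold higher number from compound 2 to compound 3 (0.12 log units; within the scatter). Compound 3 therefore stands second highest of the three numbers, within the scatter of compound 2 and separated from compound 1.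

Compound 4 `COc1ccc(C(=O)Nc2c(Cl)cncc2Cl)cc1OC1CCCCC1` differs from compound 3 only at the amide nitrogen: 3,5-dichloropyridin-4-yl in place of 2,6-difluorophenyl on an amide-type nitrogen. For the measured compounds named here, none of the measured steps touches this part of the molecule; all three concern the ether on the core, so no measured step bears on the change, and no direction can be read from the series itself. The expectation for compound 4 rests on that absence of precedent and is kept wide. Compound 4 is estimated at 150 nM, with a range from 25 nM to 900 nM. The step this estimate implies, a 2.7-fold lower number from compound 3 to compound 4 (0.43 log units; beyond the scatter), is expected to be of uncertain size and is not anchored by any step seen so far.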

Compound 4, half-maximal inhibitory concentration: 50 nM
Beside the measured number, compound 4's estimate is 3.0-fold (0.48 log units) above it; low and high end bracket the measured number.
By their numbers in this assay, from the lowest: compound 4; then compounds 2 and 3 (each within the scatter of the next); then compound 1.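

In this assay the amide nitrogen turns out to be a place in the molecule that responds strongly to change: an 8.0-fold lower number from compound 3 to compound 4 (0.90 log units; beyond the scatter), a larger step than the biggest one on the ether side of the shared core, a 3.0-fold lower number from compound 1 to compound 2 (0.48 log units; beyond the scatter). The two groups have the same heavy-atom count, but 3,5-dichloropyridin-4-yl brings a ring nitrogen with a hydrogen-bond acceptor and chlorine, while 2,6-difluorophenyl has carbon only in the ring, no acceptor and fluorine, so this single step cannot assign the change to the ring nitrogen or to the halogen. Nothing in the data at hand accounts for the size of this step.

The compounds shown leave open whether a dichlorophenyl or a difluoropyridinyl group on the amide-type nitrogen would keep the number of compound 4, which would separate the halogen from the ring nitrogen. They also leave open whether 3,5-dichloropyridin-4-yl gives a step of similar size when paired with the butyl ether of compound 2 or the methyl ether of compound 1, rather than with the cyclohexyl ether.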